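The source may report more compounds than this note shows. Statements on the series, on what has been measured and on what is new or still open speak of the compounds shown alone.

Among the measured compounds shown here, in a functional assay on K562 cells (Homo sapiens) for inhibition, read by CCK-8 assay, with a stated time of 72 h (on this read-out lower numbers stand for stronger inhibition and higher numbers for weaker inhibition), three compounds of one series have numbers so far. Compound 1 (`O=C(/C=C/c1cccnc1)NCCCCCc1cccc(S(=O)(=O)Nc2ccccc2)c1`) gives 16.3 nM, compound 2 (`O=C(/C=C/c1cccnc1)NCCCCCCCc1cccc(S(=O)(=O)Nc2ccccc2)c1`) gives 61.1 nM, and compound 3 (`Cc1ccccc1NS(=O)(=O)c1cccc(CCCCCCNC(=O)/C=C/c2cccnc2)c1`) gives 0.456 nM, the lowest of the three and beyond the scatter of both others. Compound 4 (`O=C(/C=C/c1cccnc1)NCCCCCCc1cccc(S(=O)(=O)Nc2ccc(Cl)cc2)c1`) carries 4-chlorophenyl in place of 2-methylphenyl on a sulfonamide nitrogen. For the measured compounds named here, no measured pair shows this change alone, so the expectation is loose. A higher number is expected because compound 3 at 0.456 nM stands far under the other two measured compounds. The expected upward step, beyond the scatter, is estimated as a 4.4-fold higher number from compound 3 to compound 4 (0.64 log units; beyond the scatter). Compound 4 is estimated at 2 nM, with an expected range of 0.3 nM to 12 nM.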

Compound 4, half-maximal inhibitory concentration: 6.41 nM
The estimate for compound 4 lay 3.2-fold (0.51 log units) below the measured number; the range from low to high includes it.
By their numbers in this assay, from the lowest: compound 3; then compound 4; then compound 1; then compound 2.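

In this assay, the group on the sulfonamide nitrogen proves to matter on its own: 4-chlorophenyl in place of 2-methylphenyl gives a 14-fold higher number from compound 3 to compound 4 (1.15 log units; beyond the scatter). Among the compounds shown here, this is the first pair that differs in one place, so the sensitivity of this position can now be read directly. No measurement at hand explains the step.

From the compounds shown here alone, the two compounds change the methyl and the chlorine together, so the part each plays stays open. Going by these compounds, how a plain phenyl, a 2-chlorophenyl or a 4-methylphenyl would stand on this nitrogen also remains open.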